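The compounds below may be only part of what the source reports. "The series", "measured", "known", "first", "only" and "open" are said of these compounds alone.

Measured compounds:
compound 1 `O=C1O[C@H]([C@@H](O)Cn2cc(-c3cc(F)cc(F)c3)nn2)C(OCc2ccccc2)=C1OCc1ccccc1` — 27700 nM
compound 2 `O=C1O[C@H]([C@@H](O)Cn2cc(-c3cc(C(F)(F)F)cc(C(F)(F)F)c3)nn2)C(OCc2ccccc2)=C1OCc1ccccc1` — 45900 nM
compound 3 `O=C1O/C(=C\Cn2cc(-c3cc(C(F)(F)F)cc(C(F)(F)F)c3)nn2)C(OCc2ccccc2)=C1OCc1ccccc1` — > 100000 nM

Of the compounds shown here, three sharing the core of compound 1 have been tested in a functional assay on MCF7 cells (Homo sapiens) for antiproliferative activity, read by MTT assay, with a stated time of 72 h; on this read-out lower numbers stand for stronger inhibition and higher numbers for weaker inhibition. Compound 1 gives 27700 nM there, and compound 2 gives 45900 nM; the two numbers lie within the usual scatter of each other, so neither can be set above the other. For compound 3 the assay reports only a limit, > 100000 nM, and not a number (the limit of > 100000 nM in this assay, at which 1 of the 3 values shown sits). Compound 1 thus carries one of the two real numbers in this assay, and the only one among the two lowest.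

The step now followed leads from compound 1 to compound 4 `CCCCCc1ccc(-c2cn(C[C@H](O)[C@H]3OC(=O)C(OCc4ccccc4)=C3OCc3ccccc3)nn2)cc1`. The change is 4-pentylphenyl in place of 3,5-difluorophenyl on an aromatic carbon, on the five-membered aromatic ring with three nitrogens, two ring bonds from the ring atom that bears a large group. Among the measured compounds shown here, no step between measured compounds touches this position, so there is nothing measured to lean on for its size. In this assay the author expects only a small shift, if any, that stays near the scatter, with the estimated step of a 1.5-fold lower number from compound 1 to compound 4 (0.19 log units; within the scatter). Compound 4 is therefore estimated at 18000 nM, with a range from 5000 nM to 65000 nM.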

Compound 4, half-maximal inhibitory concentration: 9010 nM
Compound 4: middle estimate off by 2.0-fold (0.30 log units), on the high side, within the range that was stated.
By their numbers in this assay, from the lowest: compound 4; then compounds 1 and 2 (each within the scatter of the next). At a limit, above all of these: compound 3.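

This position, on the five-membered aromatic ring with three nitrogens and two ring bonds from the ring atom that bears a large group, now has its first measured step. In this assay the change gives a 3.1-fold lower number from compound 1 to compound 4 (0.49 log units; beyond the scatter) and so moves the number beyond the scatter, although only modestly. Among the compounds shown here, the earlier compounds could not show this, since the only two real numbers among them, for compounds 1 and 2, lie within the scatter of each other and no step between measured compounds touched this position; nothing at hand gives a cause for the new step.

With a single change at this position, the compounds shown cannot separate what the pentyl chain contributes from what the removal of the two fluorines contributes. They also leave open whether a longer chain or a shorter one in place of the pentyl chain would move the number further, and whether an amine or a carboxylic acid at the end of that chain would keep the step.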